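Nitro substitution on a bis-anilino core: expected cytotoxicity

This account rests on a few compounds, and the source may have more. Where it says the series, first, only, none or still open, it means among the compounds named here.

Compound 1 `O=[N+]([O-])c1ccc2nc(Nc3ccc(F)c(C(F)(F)F)c3)c(Nc3ccc(F)c(C(F)(F)F)c3)nc2c1`: 670 nM
Compound 2 `Brc1ccc(Nc2nc3ccccc3nc2Nc2ccc(Br)cc2)cc1`: 4640 nM

Two compounds were tested in a toxicity assay on HepG2 cells (Homo sapiens) for cytotoxicity, read by MTT assay, with a stated time of 72 h; on this read-out higher numbers stand for lower toxicity in this test and lower numbers for higher toxicity in this test. Compound 2 stands highest of the two numbers in this assay, with 4640 nM; the nearest is compound 1, whose 670 nM is a markedly lower number, a gap that lies beyond the scatter. Compound 1 and compound 2 differ in more than one place, so the two values only show that the compound bearing the nitro group and trifluoromethyl-substituted anilines sits well below the dibromo analogue.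

Compound 3 `O=[N+]([O-])c1ccc2nc(Nc3ccc(Br)cc3)c(Nc3ccc(Br)cc3)nc2c1` has not yet been measured. It differs from compound 2 in a single place: nitro in place of hydrogen on an aromatic carbon. Going by the values given here, since no single-change step between measured compounds is available, the expected size of this step rests on the comparison of compound 1 with compound 2 alone, which points toward a lower number for compound 3, though a step within the scatter cannot be excluded. Compound 3 is accordingly estimated to give 2000 nM in this assay, with a range from 600 nM to 6000 nM, an expected step of a 2.3-fold lower number from compound 2 to compound 3 (0.37 log units; beyond the scatter).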

Compound 3, half-maximal cytotoxic concentration: 3970 nM
Estimate against measurement, compound 3: 2.0-fold (0.30 log units) below, and the stated range covers the measured number.
By their numbers in this assay, from the lowest: compound 1; then compounds 3 and 2 (each within the scatter of the next).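

In this assay, the step isolates one change: nitro in place of hydrogen on an aromatic carbon, meta to a fused ring and para to a fused ring, gives a 1.2-fold lower number from compound 2 to compound 3 (0.07 log units; within the scatter). With the two bromine-bearing anilines held constant, adding the nitro group at this place therefore does not move the read-out beyond the scatter, something that compound 1 and compound 2 could not show, as they differ in more than one place. No measurement shown here explains why this change leaves the number within the scatter.

The compounds shown leave open whether an amine or a carboxylic acid at this same aromatic carbon would also stay within the scatter, and whether nitro would do so at another aromatic carbon of that ring. They also leave open whether the same nitro step would hold with the fluorine- and trifluoromethyl-bearing anilines of compound 1, and how far those anilines alone would shift the number when the rest of the structure is kept the same.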